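The source may report more compounds than this note shows. Statements on the series, on what has been measured and on what is new or still open speak of the compounds shown alone.

Within the data shown here, in a functional assay on HeLa cells (Homo sapiens) for cytotoxicity, read by sulforhodamine B assay, with a stated time of 72 h (on this read-out higher numbers stand for weaker inhibition and lower numbers for stronger inhibition), compound 1 (`COc1cccc(/C=C/C(=O)Nc2cc(OC)c(OC)c(OC)c2)c1`) gives 11300 nM as the only exact number so far. Compound 2 (`COc1ccc(NC(=O)/C=C/c2cc(OC)c(OC)c(OC)c2)cc1`) gives > 50000 nM which is a limit of the assay and not a number. Compound 3 (`COc1cc(NC(=O)/C=C/c2cccc(OCc3ccccc3)c2)cc(OC)c1OC`) is the unmeasured relative of compound 1, with methoxy changed to benzyloxy: phenyl in place of hydrogen on a saturated chain carbon bound to an oxygen on an aromatic ring with phenyl in place of hydrogen on a saturated chain carbon bound to an oxygen on an aromatic ring. Among the measured compounds shown here, no measured pair tests this change, and in this assay the estimated step of a 1.3-fold lower number from compound 1 to compound 3 (0.10 log units; within the scatter) is expected to stay within the scatter, with no firm direction. Compound 3 is expected near 9000 nM with an estimated range from 2500 nM to 35000 nM around that value.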

Compound 3, half-maximal inhibitory concentration: 2100 nM
Compound 3: the middle estimate sits 4.3-fold (0.63 log units) above what was measured; the whole stated range lies above it.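

In this assay, phenyl in place of hydrogen on a saturated chain carbon bound to an oxygen on an aromatic ring gives a 5.4-fold lower number from compound 1 to compound 3 (0.73 log units; beyond the scatter). Among these compounds, this is the first firm step at this position, and it shows that benzyloxy is accepted there in place of methoxy, with stronger inhibition rather than weaker. Nothing given here bears on why the number falls.

A single step cannot separate the phenyl ring from the longer chain alone. Going by these compounds, how ethoxy, or a benzyloxy group carrying an amine or a carboxylic acid on its phenyl, would read stays open.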